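Adding a Sulfamoyl Group to Compound 3

The compounds below may be only part of what the source reports. "The series", "measured", "known", "first", "only" and "open" are said of these compounds alone.

Measured in an ADME assay on MT4 cells (Homo sapiens) for cytotoxicity, read by MTT assay, with a stated time of 5 days; on this read-out lower numbers stand for higher toxicity in this test and higher numbers for lower toxicity in this test:
- compound 1 `Cc1cc(C)cc(S(=O)(=O)n2c(SCC(=O)Nc3ccccc3C(=O)O)nc3ccccc32)c1`: 25200 nM
- compound 2 `Cc1cc(C)cc(S(=O)(=O)n2c(SCC(=O)Nc3ccc(S(C)(=O)=O)cc3)nc3ccccc32)c1`: 10600 nM
- compound 3 `Cc1cc(C)cc(S(=O)(=O)n2c(SCC(=O)Nc3ccccc3Cl)nc3ccccc32)c1`: 107000 nM

Compound 3 has the highest number of the three, which makes it the least toxic in this assay. Compound 4 `Cc1cc(C)cc(S(=O)(=O)n2c(SCC(=O)Nc3ccc(S(N)(=O)=O)cc3Cl)nc3ccccc32)c1` keeps all of compound 3 and gains one group: sulfamoyl in place of hydrogen on an aromatic carbon. This is sulfamoyl in place of hydrogen on an aromatic carbon, meta to a chloro group.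

For the measured compounds named here, no measured step adds sulfamoyl itself. The closest match is the 4-(methylsulfonyl)phenyl group of compound 2, and the swap to 2-chlorophenyl gave a 10-fold higher number from compound 2 to compound 3 (1.00 log units; beyond the scatter). The other steps, a 2.4-fold lower number from compound 1 to compound 2 (0.38 log units; beyond the scatter) and a 4.2-fold higher number from compound 1 to compound 3 (0.63 log units; beyond the scatter), show how far this aryl group alone can move the number. Compound 4 also retains the chloro group that compound 2 lacks, so only part of that gap is expected to reappear. The expected change is a 3.6-fold lower number from compound 3 to compound 4 (0.55 log units; beyond the scatter). The estimate for compound 4 is 30000 nM, with an expected range of 9000 nM to 100000 nM.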

Compound 4, half-maximal cytotoxic concentration: 25600 nM
Compound 4: middle estimate off by 1.2-fold (0.07 log units), on the high side; the range from low to high includes it.
By their numbers in this assay, from the lowest: compound 2; then compounds 1 and 4 (each within the scatter of the next); then compound 3.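

In this assay, adding sulfamoyl to the ring of compound 3 lowers the number even with the chloro group kept (a 4.2-fold lower number from compound 3 to compound 4 (0.62 log units; beyond the scatter)). The 2-chloro-4-sulfamoylphenyl group still gives a different number from 4-(methylsulfonyl)phenyl (a 2.4-fold higher number from compound 2 to compound 4 (0.38 log units; beyond the scatter)), yet it cannot be told apart from 2-carboxyphenyl (a 1.0-fold higher number from compound 1 to compound 4 (0.01 log units; within the scatter)). No measurement shown here explains these shifts.

Going by these compounds, whether an amine or a carboxylic acid at this same place would move the number as far as sulfamoyl remains open. So does the outcome of sulfamoyl without the chloro group.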